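Tetrahydroisoquinoline-amine series: piperidinyl to dimethylcyclohexyl on the outer amine

The compounds below may be only part of what the source reports. "The series", "measured", "known", "first", "only" and "open" are said of these compounds alone.

Working notes on the series. Compound 1 `c1cncc(CNCCCCN(C[C@H]2Cc3ccccc3CN2)[C@H]2CCCc3cccnc32)c1` carries a (pyridin-3-yl)methyl group on the outer amine nitrogen. In a functional assay on cells for agonist activity at C-X-C chemokine receptor type 4 (Homo sapiens), read by fluorescence and calcium flux, with a stated time of 90 s (on this read-out higher numbers stand for an effect only at larger amounts of compound and lower numbers for an effect already at smaller amounts), compound 1 returns only a limit, > 30000 nM. Compound 2 `c1ccc2c(c1)CN[C@@H](CN(CCCCNC1CCCCC1)[C@H]1CCCc3cccnc31)C2` has cyclohexyl there instead, and in this assay compound 2 also stands at a limit, > 30000 nM. Compound 3 `c1ccc2c(c1)CN[C@@H](CN(CCCCNC1CCNCC1)[C@H]1CCCc3cccnc31)C2` carries piperidin-4-yl, and in this assay compound 3 again gives only a limit, > 30000 nM. The steps a step that the two limits leave unreadable from compound 1 to compound 2, a step that the two limits leave unreadable from compound 1 to compound 3 and a step that the two limits leave unreadable from compound 2 to compound 3 are therefore not readable; all three values sit at the same limit (the limit of > 30000 nM in this assay, at which 3 of the 3 values shown sit).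

Compound 4 `CC1(C)CCC(NCCCCN(C[C@H]2Cc3ccccc3CN2)[C@H]2CCCc3cccnc32)CC1` is not yet measured. It differs from compound 3 by 4,4-dimethylcyclohexyl in place of piperidin-4-yl on an amine nitrogen. The nearest measured step is from compound 2 to compound 3, cyclohexyl against piperidin-4-yl, and it too is hidden by the limit. With every neighbour at the limit, no step beyond the scatter can be read, and compound 4 is expected to sit at or near the same limit in this assay, so the expected step that the limit leaves unreadable from compound 3 to compound 4 is essentially none. The estimate for compound 4 is 40000 nM, with a range from 15000 nM to 120000 nM.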

Compound 4, half-maximal effective concentration: > 30000 nM
Compound 4: no number, only a limit; the forecaster's own chance of this, stated with the estimate: 85%; the middle value lies beyond the limit too.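

Going by these compounds alone, no step from compound 1, compound 2 or compound 3 to compound 4 can be read in this assay because every value is only a limit: the limit of > 30000 nM in this assay, at which 4 of the 4 values shown sit. The compounds shown leave open whether any group on an amine nitrogen of this series gives a measurable value in this assay at all.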